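Lengthening the Alkoxy Arm of a Melatonin Receptor Ligand

This account rests on a few compounds, and the source may have more. Where it says the series, first, only, none or still open, it means among the compounds named here.

Measured compounds:
compound 1 `CCOc1ccc(OC)cc1CCCNC(C)=O` — 183 nM
compound 2 `CCCOc1ccc(OC)cc1CCCNC(C)=O` — 400 nM

In an assay on CHO cells for displacement of a labelled ligand from melatonin receptor type 1A (Homo sapiens), read by scintillation counting, with a stated time of 60 min (a higher number here means a weaker inhibitor, a lower number a stronger inhibitor), compound 1 gives 183 nM and stands at the lowest of the two numbers recorded so far; its nearest neighbour is compound 2 with 400 nM. Among the compounds with values here, the single measured step, a 2.2-fold higher number from compound 1 to compound 2 (0.34 log units; beyond the scatter), arises from a methyl in place of hydrogen on a saturated chain carbon, two bonds along the chain from an oxygen on an aromatic ring, and it is modest but beyond the scatter.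

Compound 3 `COc1cccc(COc2ccc(OC)cc2CCCNC(C)=O)c1` has not yet been measured. It departs from compound 1 by 3-methoxyphenyl in place of methyl on a saturated chain carbon bound to an oxygen on an aromatic ring. Within the data shown here, the only step that bears on this change is a 2.2-fold higher number from compound 1 to compound 2 (0.34 log units; beyond the scatter), which shows that growth of the alkoxy arm by a single carbon already raises the number. Among the measured compounds shown here, compound 3 carries a far larger extension at the same arm, so a step of similar or somewhat greater size in the weakening direction is expected in this assay, though with wide uncertainty since no ring-bearing analogue has been measured. The estimate for compound 3 is therefore 600 nM (range 150 nM to 3000 nM), corresponding to an expected step of a 3.3-fold higher number from compound 1 to compound 3 (0.52 log units; beyond the scatter).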

Compound 3, inhibition constant: 441 nM
The estimate for compound 3 lay 1.4-fold (0.13 log units) above the measured number; the range from low to high includes it.
By their numbers in this assay, from the lowest: compound 1; then compounds 2 and 3 (each within the scatter of the next).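

In this assay, 3-methoxyphenyl in place of methyl on a saturated chain carbon bound to an oxygen on an aromatic ring gives a 2.4-fold higher number from compound 1 to compound 3 (0.38 log units; beyond the scatter) even though 8 heavy atoms and one six-membered aromatic ring enter where 1 heavy atom leaves, so this position accepts a far larger group at a modest cost. Set against the shorter arm of compound 2, the same group, here in place of ethyl, gives a 1.1-fold higher number from compound 2 to compound 3 (0.04 log units; within the scatter) and thus leaves the two compounds indistinguishable, which shows that the number does not keep climbing in step with the size of the arm across these three compounds. No measurement offered here accounts for this flat response.

The compounds shown leave open whether the methoxy on the new ring contributes anything, since an unsubstituted phenyl at this carbon would be needed to tell, and whether moving that methoxy elsewhere on the ring would alter the number. They also leave open how an amine, a carboxylic acid or a longer chain carrying the ring would fare at the same carbon.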